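Pyridin-3-yl in Place of 3-Bromophenyl: Expectation for Compound 4

A few compounds are considered here, and "the series" means these few. Any claim that something is new, unique, unknown or untested is made for them only; others in the source may bear on it.

Within the data shown here, compound 1 `CC(=O)N1N=C(c2ccc3ccccc3c2)OC1c1cccc(Br)c1` gives 1.68 ug/mL in a functional assay on HepG2 cells (Homo sapiens) for antiproliferative activity, read by MTT assay, with a stated time of 48 h (a lower number here means a stronger inhibitor, a higher number a weaker inhibitor), the lowest of the three numbers so far. Compound 2 `CC(=O)N1N=C(c2ccc3ccccc3c2)OC1c1ccccc1Cl` gives 4.32 ug/mL and compound 3 `CC(=O)N1N=C(c2ccc3ccccc3c2)OC1c1ccc(Cl)cc1` gives 1.88 ug/mL. The measured steps are a 2.6-fold higher number from compound 1 to compound 2 (0.41 log units; beyond the scatter), a 1.1-fold higher number from compound 1 to compound 3 (0.05 log units; within the scatter) and a 2.3-fold lower number from compound 2 to compound 3 (0.36 log units; beyond the scatter). Compound 4 `CC(=O)N1N=C(c2ccc3ccccc3c2)OC1c1cccnc1` differs from compound 1 by pyridin-3-yl in place of 3-bromophenyl on a saturated ring carbon. Among the measured compounds shown here, none of the measured steps exchanges a phenyl ring for a pyridin-3-yl, so they bear only loosely on this change; they show that swaps on this saturated ring carbon move the number by little or by a modest amount. A modest weakening is expected, giving a 1.8-fold higher number from compound 1 to compound 4 (0.25 log units; within the scatter). Compound 4 is therefore estimated at 3 ug/mL, within a range from 1.2 ug/mL to 7.5 ug/mL.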

Compound 4, half-maximal inhibitory concentration: 2.86 ug/mL
Beside the measured number, compound 4's estimate is 1.0-fold (0.02 log units) above it, and the stated range covers the measured number.
By their numbers in this assay, from the lowest: compounds 1, 3, 4 and 2 (each within the scatter of the next, the first and the last beyond it).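

In this assay, among these compounds, the earlier compounds all carried a halogen on a phenyl ring, and compound 4 shows that pyridin-3-yl, with no halogen, also sits on this saturated ring carbon with a number within the scatter of all three: (a 1.7-fold higher number from compound 1 to compound 4 (0.23 log units; within the scatter)), (a 1.5-fold higher number from compound 3 to compound 4 (0.18 log units; within the scatter)) and (a 1.5-fold lower number from compound 2 to compound 4 (0.18 log units; within the scatter)). Among the compounds shown here, the gap that separates compound 2 from compounds 1 and 3 has no counterpart in any step to compound 4.

Going by these compounds, how an amine or a carboxylic acid on this ring carbon would read stays open. Nothing given here explains the result.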